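The compounds below may be only part of what the source reports. "The series", "measured", "known", "first", "only" and "open" are said of these compounds alone.

Measured in an ADME assay on microsomes from liver (Homo sapiens) for metabolic stability, read by LC-MS, using NADPH, with a stated time of 30 min, tested at 1 uM; on this read-out higher numbers stand for fast clearance and lower numbers for slow clearance:

Compound 1 `CC(C)c1noc(N2CCC(Oc3cc(N4CCc5cc(N6CCCNS6(=O)=O)ccc54)ncn3)CC2)n1`: 79 mL.min-1.g-1
Compound 2 `CC(C)c1noc(N2CCC(Oc3cc(N4CCc5cc(S(C)(=O)=O)ccc54)ncn3)CC2)n1`: 69 mL.min-1.g-1

Among the compounds with values here, compound 1 and compound 2 lie within the usual scatter of each other, so compound 1 stands level with the only other measured compound. Compound 3 `CC(C)c1noc(N2CCC(Oc3cc(N4CCc5cc(N6CCC(O)CC6=O)ccc54)ncn3)CC2)n1` keeps the shared core of compound 1 and changes one group: a group of 8 heavy atoms (5 carbon, 1 nitrogen, 2 oxygen; one six-membered non-aromatic ring with 1 hetero atom) in place of a group of 8 heavy atoms (3 carbon, 2 nitrogen, 2 oxygen, 1 sulfur; one six-membered non-aromatic ring with 3 hetero atoms), on an aromatic carbon. The incoming 4-hydroxy-2-oxopiperidin-1-yl sits on an aromatic carbon of a six-membered aromatic ring of carbon only, where the group it replaces stood.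

Within the data shown here, one measured step bears on this change. It is a 1.1-fold lower number from compound 1 to compound 2 (0.06 log units; within the scatter), and it replaces a group at this same place. Among the measured compounds shown here, that single step is thin evidence, and no measured compound yet carries the incoming group. Even so, compound 2 gives no sign that this assay responds strongly to a change at this place, so no shift beyond the scatter is expected. The expected step is a 1.2-fold lower number from compound 1 to compound 3 (0.08 log units; within the scatter). For compound 3 the estimated value is 65 mL.min-1.g-1, with an expected range from 32 mL.min-1.g-1 to 125 mL.min-1.g-1.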

Compound 3, intrinsic clearance in microsomes: 4 mL.min-1.g-1
Estimate against measurement, compound 3: 16-fold (1.21 log units) above, and the stated range ends above it.
By their numbers in this assay, from the lowest: compound 3; then compounds 2 and 1 (each within the scatter of the next).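

With 4-hydroxy-2-oxopiperidin-1-yl on the aromatic carbon, this assay shows a 20-fold lower number from compound 1 to compound 3 (1.30 log units; beyond the scatter) and also a 17-fold lower number from compound 2 to compound 3 (1.24 log units; beyond the scatter) where it replaces methylsulfonyl. Within the data shown here, this place is therefore far from indifferent to what stands on it: compound 1 and compound 2, both carrying sulfur in this group, stand level, while compound 3, with no sulfur there, lies well apart from both, even though its group matches the one in compound 1 in heavy atoms, donors and acceptors. Nothing available here accounts for the drop in clearance.

The compounds shown do not tell whether the hydroxyl group or the ring carbonyl matters more, since the two enter together; the same ring without the hydroxyl group, or a piperidine ring that keeps the hydroxyl group but lacks the carbonyl, would separate them. As far as these compounds go, it also remains open whether a morpholine ring or a carboxylic acid at this place would give a similarly low number, and whether the low number would hold on a different core, as all three compounds share one.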